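A Hydroxyl Added to the Amide Chain of Compound 2

The compounds below may be only part of what the source reports. "The series", "measured", "known", "first", "only" and "open" are said of these compounds alone.

Compound 2 (`CCNC(=O)c1c(NO)cc(-c2ccccc2)oc1=O`) carries an ethyl group on its amide nitrogen. In an ADME assay on Huh-7 cells (Homo sapiens) for cytotoxicity, read by a luciferase reporter and WST assay, with a stated time of 3 days (a higher number here means that more compound is tolerated, a lower number that less compound is tolerated), compound 2 reaches only the assay limit of > 20000 nM, which is a limit and not a measured number. Compound 1 (`O=C(Nc1ccc(O)cc1)c1c(NO)cc(-c2ccccc2)oc1=O`) bears a 4-hydroxyphenyl group in the same place. In this assay compound 1 likewise stops at the limit of > 20000 nM. The step that the two limits leave unreadable from compound 1 to compound 2 therefore cannot be read, because of the limit of > 20000 nM in this assay, at which 2 of the 2 values shown sit. Compound 3 (`O=C(NCCCO)c1c(NO)cc(-c2ccccc2)oc1=O`) differs from compound 2 by hydroxymethyl in place of hydrogen on a saturated chain carbon, two bonds along the chain from an amide-type nitrogen. Among the compounds with values here, no measured step covers this change, and the single measured step gives no size, so a step beyond the scatter is neither indicated nor ruled out. Compound 3 is expected to remain at or past the same limit, an estimated step that the limit leaves unreadable from compound 2 to compound 3. The estimate for compound 3 in this assay is 30000 nM, with a range from 15000 nM to 80000 nM.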

Compound 3, half-maximal cytotoxic concentration: > 20000 nM
Compound 3: only a limit was reported; the forecaster's own chance of this, stated with the estimate: 80%; the middle value is on the limit's open side.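

Compound 1, compound 2 and compound 3 all stop at a limit in this assay, so no step among them can be read: the limit of > 20000 nM in this assay, at which 3 of the 3 values shown sit.

The compounds shown leave open whether the 4-hydroxyphenyl, ethyl and 3-hydroxypropyl groups on the amide nitrogen differ at all in how much compound the cells tolerate.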